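This account rests on a few compounds, and the source may have more. Where it says the series, first, only, none or still open, it means among the compounds named here.

Of the compounds shown here, three have been tested in an assay on isolated protein for inhibition of DNA topoisomerase 1 (Homo sapiens), with a stated time of 30 min, tested at 100 uM; a lower number here means a weaker effect, a higher number a stronger effect of the compound at the concentration tested. Compound 1 `COc1ccc(-c2cc3ccccc3c(-c3cccc(O)c3)n2)cc1` gives 9.4%. Compound 2 `COc1ccc(-c2cc3ccccc3c(-c3cccc(OC)c3)n2)cc1` differs from compound 1 in one place: methyl in place of hydrogen on an oxygen on an aromatic ring. In this assay compound 2 gives 43.2%, so this single change made a step of a number 33.8 percentage points higher from compound 1 to compound 2 (beyond the scatter). Compound 3 `COc1ccc(-c2cc3cc(C)ccc3c(-c3cccc(O)c3)n2)cc1OC` is built on a different core, and how its core differs from that of compound 1 is not broken down here. In this assay compound 3 gives 1.7%, which lies within the usual scatter of the value of compound 1 and well apart from the value of compound 2.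

Compound 4 `COc1cccc(-c2nc(-c3ccc(OC)c(OC)c3)cc3cc(C)ccc23)c1` has not yet been measured. It differs from compound 3 by methyl in place of hydrogen on an oxygen on an aromatic ring, the same change as that between compound 1 and compound 2, made at a place described in the same words on both cores. Because a number 33.8 percentage points higher from compound 1 to compound 2 (beyond the scatter) was a large step, a step of roughly that size is expected here as well. The expected step is a number 28.3 percentage points higher from compound 3 to compound 4 (beyond the scatter). The core is different and the change has been seen only once, so the expectation is loose. Compound 4 is therefore estimated at 30%, with a likely range from 10% to 55%.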

Compound 4, a percentage reported as inhibition, at one concentration (the size of the read-out at that concentration, not a potency): 2.9%
Estimate against measurement, compound 4: 27.1 percentage points above, outside the stated range (below it).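

On the core of compound 3, the change from hydroxy to methoxy gave a number 1.2 percentage points higher from compound 3 to compound 4 (within the scatter) in this assay, so the large gain seen on the core of compound 1 did not carry over to this second core. Among the compounds shown here, the two results for the same change differ by more than repeated measurements would be expected to explain, so the effect of this change depends on the core that carries it: the same change on two cores in this assay, a number 33.8 percentage points higher (beyond the scatter) from compound 1 to compound 2 and a number 1.2 percentage points higher (within the scatter) from compound 3 to compound 4, 32.6 percentage points apart, beyond the scatter of two such steps This does not show which feature of the two cores matters, since they are not broken down here into single differences, and with only one pair on each core it gives no general rule for how the change will behave on any further core.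

The compounds shown leave open whether a different group in place of the hydroxy, such as an amine or a longer chain like butoxy, could raise the read-out on the core of compound 3. Each result is the size of the effect at a single concentration, so these compounds can be compared only for a stronger or weaker effect at that concentration.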